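The source may report more compounds than this note shows. Statements on the series, on what has been measured and on what is new or still open speak of the compounds shown alone.

Going by the values given here, in a functional assay on PC-3 cells (Homo sapiens) for inhibition, read by sulforhodamine B assay, with a stated time of 48 h (a higher number here means a weaker inhibitor of growth, a lower number a stronger inhibitor of growth), compound 2 `COc1ccc(Sc2nc3cc(N)cc(N)c3nc2-c2ccccc2)cc1` gives 5130 nM, the only number reported among the two compounds measured so far. Compound 1 `CCOC(=O)[C@H](CCC(=O)O)NC(=O)c1ccc(Sc2nc3cc(N)cc(N)c3nc2-c2ccccc2)cc1` is known in this assay only as a limit, < 100000 nM. Compound 3 `Nc1cc(N)c2nc(-c3ccccc3)c(Sc3ccc(F)cc3)nc2c1` has not yet been measured in this assay. It differs from compound 2 in a single place: fluoro in place of methoxy on an aromatic carbon. Among the compounds with values here, no two measured compounds differ from each other in only one place, so there is no measured step to lean on for a change of this kind, and the estimate below rests on compound 2 alone together with the small size of the change. The step in this assay is expected to be a 1.2-fold higher number from compound 2 to compound 3 (0.07 log units; within the scatter), a shift that should stay within the usual scatter of repeated measurements. Compound 3 is therefore expected to give about 6000 nM in this assay, with a plausible range from 2000 nM to 18000 nM.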

Compound 3, concentration for total growth inhibition: < 100000 nM
Compound 3: only a limit was reported (the forecaster's own chance of this, stated with the estimate: 5%); the middle value is on the limit's open side.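

In this assay, going by these compounds alone, compound 3 is known only as a limit, < 100000 nM, so no step from compound 2 to compound 3 can be read. The compounds shown leave open how fluoro in place of methoxy on an aromatic carbon alters growth inhibition.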